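Swapping an Amino Alcohol Chain for a Piperazine Ring

The compounds below may be only part of what the source reports. "The series", "measured", "known", "first", "only" and "open" are said of these compounds alone.

Compound 1 `CS(=O)(=O)Oc1c(C(=O)NCc2ccc(F)cc2)nc(Br)c2cccnc12`: "not determined" (no result reported)
Compound 2 `N[C@H]1CC[C@H](Nc2c(C(=O)NCc3ccc(F)cc3)nc(Br)c3cccnc23)CC1`: 2000 nM
Compound 3 `O=C(NCc1ccc(F)cc1)c1nc(Br)c2cccnc2c1NCCO`: "not determined" (no result reported)

These three compounds share one core and differ only in the group attached at a single aromatic carbon. In a functional assay on MCF7 cells (Homo sapiens) for cytotoxicity, read by MTT assay, with a stated time of 72 h (on this read-out lower numbers stand for stronger inhibition and higher numbers for weaker inhibition), compound 2 gives 2000 nM. For compound 3 no number is available in this assay, and the same is true of compound 1, so compound 3 cannot be placed against any measured neighbour; only compound 2 offers a figure from this series at all.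

Compound 4 `O=C(NCc1ccc(F)cc1)c1nc(Br)c2cccnc2c1N1CCNCC1` is the next compound to be measured. It differs from compound 3 in one place: piperazin-1-yl in place of (2-hydroxyethyl)amino on an aromatic carbon. Going by the values given here, with no measured pair of this kind to compare, the size and direction of this step in this assay cannot be read from the data; it may equally fall within the scatter or go either way beyond it.

Among the compounds with values here, on the single measured value of compound 2 as the only anchor, compound 4 is expected to give about 3000 nM in this assay, with a plausible range from 600 nM to 15000 nM.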

Compound 4, half-maximal inhibitory concentration: 7000 nM
For compound 4 the middle estimate is 2.3-fold (0.37 log units) below the measured one; the range from low to high includes it.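

Moving from (4-aminocyclohexyl)amino to piperazin-1-yl on this aromatic carbon in this assay gives a 3.5-fold higher number from compound 2 to compound 4 (0.54 log units; beyond the scatter) and so provides the first comparison in the series. It shows that the number can shift beyond the usual scatter when one nitrogen-linked group at this position is replaced by another, and that this replacement weakens inhibition rather than strengthens it. The step between compound 3 and compound 4 cannot be read, as compound 3 has no number, and no measurement shown here accounts for the shift between compound 2 and compound 4.

Still open, going by these compounds, is how a morpholine ring or a plain amino group on this carbon would compare with piperazin-1-yl. Also open, on these data alone, is whether the same step would hold with a chloro group in place of the bromo group.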